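The compounds below may be only part of what the source reports. "The series", "measured", "known", "first", "only" and "open" are said of these compounds alone.

Measured so far in a functional assay on HeLa cells (Homo sapiens) for inhibition, read by MTT assay, with a stated time of 72 h; on this read-out higher numbers stand for weaker inhibition and lower numbers for stronger inhibition:
compound 1 `O=c1cc(Cn2cc(CCCCl)nn2)c2ccc(O)cc2o1`: 49600 nM
compound 2 `O=c1cc(Cn2cc(CNS(=O)(=O)c3ccc([N+](=O)[O-])cc3)nn2)c2ccc(O)cc2o1`: > 100000 nM, which is a limit of the assay and not a number.

Among the measured compounds shown here, compound 1 thus holds the only number in this assay; the one other value is a limit, (the limit of > 100000 nM in this assay, at which 1 of the 2 values shown sits), so no measured step between compounds is available and nothing indicates how far a change at this position can move the read-out.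

Compound 3 `O=c1cc(Cn2cc(CSC(=S)N3CCNCC3)nn2)c2ccc(O)cc2o1` differs from compound 1 by a group of 9 heavy atoms (5 carbon, 2 nitrogen, 2 sulfur; one six-membered non-aromatic ring with 2 hetero atoms) in place of a group of 3 heavy atoms (2 carbon, 1 chlorine; no ring), on a saturated chain carbon bound to an aromatic carbon. For the measured compounds named here, with no measured step to lean on, the direction is uncertain; a shift towards stronger inhibition is expected, of moderate size but with a wide range around it, and a step no larger than the scatter is also plausible. Compound 3 is expected to give 20000 nM in this assay, in the range 5000 nM to 80000 nM. The expected step is a 2.5-fold lower number from compound 1 to compound 3 (0.39 log units; beyond the scatter).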

Compound 3, half-maximal inhibitory concentration: > 100000 nM
Compound 3: a limit, no number (the forecaster's own chance of this, stated with the estimate: 15%); at least 5.0-fold (0.69 log units) between middle value and limit.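

In this assay compound 3 gives > 100000 nM, which is a limit of the assay and not a number. The step reads as an at least 2.0-fold higher number from compound 1 to compound 3 (0.30 log units; that floor lies within the scatter), so the group with the six-membered non-aromatic ring, in place of 2-chloroethyl on the saturated chain carbon, brings no gain in inhibition, and how far the step runs past that floor cannot be read. The limit now holds most of the values shown: the limit of > 100000 nM in this assay, at which 2 of the 3 values shown sit.

Among the compounds shown here, compound 1 remains the only compound with a number, so it stays open whether any change at this place can give stronger inhibition than compound 1 does. A simple amine, a carboxylic acid or a longer chain ending in chlorine at the same place would show how much of the read-out depends on this group.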